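Swapping the sulfonamide arm for a methylphenyl group

A few compounds are considered here, and "the series" means these few. Any claim that something is new, unique, unknown or untested is made for them only; others in the source may bear on it.

For the measured compounds named here, compound 2 `CS(=O)(=O)N(CC1CCN(C(=O)[C@H](COCc2ccc(Cl)c(Cl)c2)NCc2ccccc2)CC1)c1ccccc1` holds the lower of the two numbers measured so far: in an assay on CHO cells for displacement of a labelled ligand from Substance-P receptor (Homo sapiens) (a higher number here means a weaker inhibitor, a lower number a stronger inhibitor), compound 2 gives 547 nM, while compound 1 `CS(=O)(=O)N1CCC2(CCN(C(=O)[C@H](COCc3ccc(Cl)c(Cl)c3)NCc3ccccc3)CC2)C1` gives 2500 nM in this assay. Compound 3 `Cc1ccccc1C1CCN(C(=O)[C@H](COCc2ccc(Cl)c(Cl)c2)NCc2ccccc2)CC1` differs from compound 2 by one change, (2-methylphenyl in place of ((methylsulfonyl)(phenyl)amino)methyl on a saturated ring carbon). Going by the values given here, no measured pair shows a change of this kind, so the size of the step remains a guess. The account expects a small gain, within reach of the scatter, with an expected step of a 1.8-fold lower number from compound 2 to compound 3 (0.26 log units; within the scatter). For compound 3 the estimate in this assay is 300 nM, expected to fall between 60 nM and 1500 nM.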

Compound 3, half-maximal inhibitory concentration: 330 nM
Compound 3: middle estimate off by 1.1-fold (0.04 log units), on the low side, within the range that was stated.
By their numbers in this assay, from the lowest: compounds 3 and 2 (each within the scatter of the next); then compound 1.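

At the saturated ring carbon three ring bonds from the ring nitrogen, replacing ((methylsulfonyl)(phenyl)amino)methyl with 2-methylphenyl gives a 1.7-fold lower number from compound 2 to compound 3 (0.22 log units; within the scatter) in this assay. The 12 heavy atoms of the arm, with their sulfur and 2 hydrogen-bond acceptors, thus give way to 7 carbon atoms while the two compounds stay within the scatter of each other. Nothing available gives a reason for this result.

The compounds shown leave open whether the methyl of 2-methylphenyl matters, as an unsubstituted phenyl would test. They also leave open how an amine or a carboxylic acid at this position would compare.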